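This account rests on a few compounds, and the source may have more. Where it says the series, first, only, none or still open, it means among the compounds named here.

Values in a functional assay on HeLa cells (Homo sapiens) for antiproliferative activity, read by MTT assay, with a stated time of 48 h; a higher number here means a weaker inhibitor, a lower number a stronger inhibitor:
compound 1 `Cn1cc(-c2cnc3ccnc(NC(=O)C4CC4)c3c2)cn1`: > 50000 nM, a limit
compound 2 `Cn1cc(-c2cnc3ccnc(NCc4ccc(F)cc4)c3c2)cn1`: 9200 nM
compound 3 `Cn1cc(-c2cnc3ccnc(NS(=O)(=O)c4ccc(C(F)(F)F)cc4)c3c2)cn1`: > 50000 nM, a limit

Compound 3 gives only a limit, > 50000 nM, and no number. Going by the values given here, the series so far is marked by the limit of > 50000 nM in this assay, at which 2 of the 3 values shown sit.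

Compound 4 `Cn1cc(-c2cnc3ccnc(NS(=O)(=O)c4cccs4)c3c2)cn1` carries thiophen-2-yl in place of 4-(trifluoromethyl)phenyl on a sulfonyl sulfur. Among the compounds with values here, the only measured step, an at least 5.4-fold lower number from compound 1 to compound 2 (0.73 log units; beyond the scatter), puts 4-fluorobenzyl in place of cyclopropylcarbonyl on a nitrogen on an aromatic ring. Within the data shown here, no measured step touches the group on the sulfonyl sulfur, so that step bears only indirectly. In this assay no change beyond the scatter is expected, and another limit is likely. The estimated change is an at least 1.1-fold lower number from compound 3 to compound 4 (0.04 log units; that floor lies within the scatter). Compound 4 is expected at 45000 nM, with an estimated range of 15000 nM to 100000 nM.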

Compound 4, half-maximal inhibitory concentration: 17400 nM
For compound 4 the middle estimate is 2.6-fold (0.41 log units) above the measured one; the measured number falls inside the stated range.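

On a sulfonyl sulfur, thiophen-2-yl in place of 4-(trifluoromethyl)phenyl gives a measurable value in this assay with an at least 2.8-fold lower number from compound 3 to compound 4 (0.45 log units; beyond the scatter) as the step. The sulfonamide link therefore does not by itself hold a compound at the mark of this series: the limit of > 50000 nM in this assay, at which 2 of the 4 values shown sit. On a nitrogen on an aromatic ring, (thiophen-2-yl)sulfonyl reads clear of cyclopropylcarbonyl with an at least 2.8-fold lower number from compound 1 to compound 4 (0.45 log units; beyond the scatter) as the step, while against 4-fluorobenzyl a 1.9-fold higher number from compound 2 to compound 4 (0.28 log units; within the scatter) leaves the two unordered.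

Open, going by these compounds, is whether the ring or the trifluoromethyl counts, since this step changes both at once. Plain phenyl or furan-2-yl on the sulfonyl sulfur would separate them.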